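This account rests on a few compounds, and the source may have more. Where it says the series, first, only, none or still open, it means among the compounds named here.

Measured so far in an ADME assay on HeLa cells (Homo sapiens) for cytotoxicity, read by MTT assay; a lower number here means a stronger inhibitor, a higher number a weaker inhibitor:
- compound 1, `COc1ccc(C[C@H]2COC(=O)[C@@H]2Cc2ccc(OCc3cn(Cc4ccc(Cl)cc4)nn3)c(OC)c2)cc1OC`: compound 1 gives 242000 nM
- compound 3, `COc1ccc(C[C@H]2COC(=O)[C@@H]2Cc2ccc(OCc3cn(-c4cccc(Cl)c4)nn3)c(OC)c2)cc1OC`: compound 3 gives 493000 nM
- compound 2, `COc1ccc(C[C@H]2COC(=O)[C@@H]2Cc2ccc(OCC(=O)Nc3ccccc3)c(OC)c2)cc1OC`: for compound 2 this assay reports only a limit, >= 600000 nM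

Compound 1 holds the lowest of the two numbers in this assay; its nearest neighbour is compound 3, with a 2.0-fold higher number from compound 1 to compound 3 (0.31 log units; beyond the scatter). Between compound 2 and compound 3 the step is an at least 1.2-fold lower number from compound 2 to compound 3 (0.08 log units; that floor lies within the scatter), which rests on the limit described by the limit of >= 600000 nM in this assay, at which 1 of the 3 values shown sits, and so carries little weight.

The unmeasured compound 4, `COc1ccc(C[C@H]2COC(=O)[C@@H]2Cc2ccc(OCc3cn(-c4ccc(Cl)cc4)nn3)c(OC)c2)cc1OC`, differs from compound 1 in one place: 4-chlorophenyl in place of 4-chlorobenzyl on an aromatic nitrogen. Among the compounds with values here, the measured step that bears on this is the one from compound 1 to compound 3, where the same exchange of a benzyl for a phenyl on the aromatic nitrogen, with the chlorine moved, gave a 2.0-fold higher number from compound 1 to compound 3 (0.31 log units; beyond the scatter). A step of similar size and the same direction is therefore expected for compound 4 in this assay, a 1.9-fold higher number from compound 1 to compound 4 (0.27 log units; within the scatter), though the value may reach the limit of this assay.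

Compound 4 is estimated at 450000 nM, within the range 200000 nM to 1000000 nM.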

Compound 4, half-maximal inhibitory concentration: 279000 nM
The estimate for compound 4 lay 1.6-fold (0.21 log units) above the measured number; measured number inside the range.
By their numbers in this assay, from the lowest: compounds 1, 4 and 3 (each within the scatter of the next, the first and the last beyond it). At a limit, above all of these: compound 2.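

In this assay, each single change on the aromatic nitrogen stays within the scatter, with a 1.2-fold higher number from compound 1 to compound 4 (0.06 log units; within the scatter) for 4-chlorophenyl in place of 4-chlorobenzyl and a 1.8-fold lower number from compound 3 to compound 4 (0.25 log units; within the scatter) for 4-chlorophenyl in place of 3-chlorophenyl, while the step that combines the two exchanges lies beyond it, at a 2.0-fold higher number from compound 1 to compound 3 (0.31 log units; beyond the scatter). Neither the 4-chlorobenzyl to 4-chlorophenyl exchange nor the 3-chlorophenyl to 4-chlorophenyl exchange therefore stands out alone at this position. With 1-(4-chlorophenyl)-1H-1,2,3-triazol-4-yl in place of phenylcarbamoyl, the step is an at least 2.1-fold lower number from compound 2 to compound 4 (0.33 log units; beyond the scatter), and the value at its start is a limit, not a number: the limit of >= 600000 nM in this assay, at which 1 of the 4 values shown sits.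

From the compounds shown here alone, whether a phenethyl, aminophenyl or carboxyphenyl group on the aromatic nitrogen would give a step beyond the scatter remains open.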